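Removing a Methyl from an Aromatic Oxygen: Two Parallel Cases

The compounds below may be only part of what the source reports. "The series", "measured", "known", "first", "only" and "open" are said of these compounds alone.

Compound 1 `COc1cc(-c2nn(-c3cccc(NC(=O)Nc4cc(C(F)(F)F)cc(C(F)(F)F)c4)c3)cc2-c2ccncc2)ccc1Cl` and compound 2 `O=C(Nc1cccc(-n2cc(-c3ccncc3)c(-c3ccc(Cl)c(O)c3)n2)c1)Nc1cc(C(F)(F)F)cc(C(F)(F)F)c1` share one core and differ in a single place: hydrogen in place of methyl on an oxygen on an aromatic ring. In a functional assay on IGROV-1 cells (Homo sapiens) for inhibition, read by sulforhodamine B assay, with a stated time of 48 h (a lower number here means a stronger inhibitor of growth, a higher number a weaker inhibitor of growth), compound 1 gives 826 nM, while compound 2 gives 896 nM. The measured step is a 1.1-fold higher number from compound 1 to compound 2 (0.04 log units; within the scatter), so in this pair the change left growth inhibition essentially where it was.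

Compound 3 `COc1cc(-c2nn(-c3cccc(NC(=O)Nc4ccc(Cl)c(C(F)(F)F)c4)c3)cc2-c2ccncc2)ccc1Cl` is built on a different core; how the core of compound 3 differs from that of compound 1 is not broken down here. In this assay compound 3 gives 1200 nM, a number that sits within the scatter of both compound 1 and compound 2, so no ordering among the three can be claimed.

Compound 4 `O=C(Nc1cccc(-n2cc(-c3ccncc3)c(-c3ccc(Cl)c(O)c3)n2)c1)Nc1ccc(Cl)c(C(F)(F)F)c1` has not yet been measured. It arises from compound 3 through the same change seen before: hydrogen in place of methyl on an oxygen on an aromatic ring. The surroundings of the oxygen are described identically in both pairs, so this is the same change rather than merely the same kind of change.

Among the measured compounds shown here, the only guide to its effect is the pair already measured. Because the step of a 1.1-fold higher number from compound 1 to compound 2 (0.04 log units; within the scatter) lay within the scatter, the same change on the core of compound 3 is expected to behave alike. Compound 4 is therefore estimated to give about 1300 nM in this assay, with a likely range from 600 nM to 2800 nM. The expected step is a 1.1-fold higher number from compound 3 to compound 4 (0.03 log units; within the scatter), resting on that single precedent.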

Compound 4, concentration for 50% growth inhibition: 715 nM
Estimate against measurement, compound 4: 1.8-fold (0.26 log units) above; the measured number falls inside the stated range.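

On the core of compound 3, replacing the methyl on the aromatic oxygen with hydrogen gives, in this assay, a 1.7-fold lower number from compound 3 to compound 4 (0.22 log units; within the scatter), so this step, like the earlier one, is too small to separate from ordinary repeat-to-repeat variation. Set side by side, the two steps do not differ by more than such variation allows: the same change on two cores in this assay, a 1.1-fold higher number (0.04 log units; within the scatter) from compound 1 to compound 2 and a 1.7-fold lower number (0.22 log units; within the scatter) from compound 3 to compound 4, 1.8-fold (0.26 log units) apart, within the scatter of two such steps. On these two cores, then, going from 4-chloro-3-methoxyphenyl to 4-chloro-3-hydroxyphenyl behaves alike and leaves growth inhibition within the scatter, but this does not prove that the change has no effect at all: a small real effect could still be hidden inside the scatter, and two pairs make no rule for other cores.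

Among the compounds shown, this oxygen carries only methyl or hydrogen, so it remains open whether a longer chain on the oxygen, such as ethyl, or an amine in place of the hydroxy group would produce a step large enough to read. As far as these compounds go, it also remains open whether the methoxy to hydroxy change would stay this small in a different kind of test.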